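The compounds below may be only part of what the source reports. "The series", "measured", "known", "first", "only" and "open" are said of these compounds alone.

The compounds measured in a functional assay on BJAB cells (Homo sapiens) for antiproliferative activity, with a stated time of 4 days (on this read-out higher numbers stand for an effect only at larger amounts of compound and lower numbers for an effect already at smaller amounts), are these:
Compound 1, `Cc1nn(-c2nc(-c3ccc(Cl)c(Cl)c3)c(SC(C)C)s2)c(C(=O)O)c1-c1ccccc1`, gives 3000 nM.
Compound 2, `COc1ccccc1-c1c(C)nn(-c2nc(-c3ccc(Cl)c(Cl)c3)c(SC(C)C)s2)c1C(=O)O`, gives 14700 nM.
Compound 3, `COc1cc(C#N)cc(-c2c(C)nn(-c3nc(-c4ccc(Cl)c(Cl)c4)c(SC(C)C)s3)c2C(=O)O)c1`, gives 5200 nM.

Among these three numbers compound 3 stands second highest. Its nearest neighbour is compound 1, and a 1.7-fold higher number from compound 1 to compound 3 (0.24 log units; within the scatter). Its furthest neighbour is compound 2, and a 2.8-fold lower number from compound 2 to compound 3 (0.45 log units; beyond the scatter).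

Compound 4, `Cc1nn(-c2nc(-c3ccc(Cl)c(Cl)c3)c(SC(C)C)s2)c(C(=O)O)c1-c1cccc(F)c1`, has not yet been measured in this assay. It differs from compound 3 in one place: 3-fluorophenyl in place of 3-cyano-5-methoxyphenyl on an aromatic carbon. For the measured compounds named here, two measured steps bear on this change, both starting from the unsubstituted phenyl of compound 1. The step to the 3-cyano-5-methoxyphenyl was small: a 1.7-fold higher number from compound 1 to compound 3 (0.24 log units; within the scatter). The step to the 2-methoxyphenyl was larger: a 4.9-fold higher number from compound 1 to compound 2 (0.69 log units; beyond the scatter). The 3-fluorophenyl of compound 4 carries neither a methoxy nor a nitrile, so the picture from compound 1 and compound 3 is the closer guide. The step from compound 3 to compound 4 in this assay is therefore expected to stay within the scatter, or at most to be a small move toward a lower number, a 1.5-fold lower number from compound 3 to compound 4 (0.17 log units; within the scatter). For compound 4 the estimate in this assay is 3500 nM, with a range from 1500 nM to 8000 nM.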

Compound 4, half-maximal effective concentration: 900 nM
Estimate against measurement, compound 4: 3.9-fold (0.59 log units) above, and the stated range ends above it.
By their numbers in this assay, from the lowest: compound 4; then compounds 1 and 3 (each within the scatter of the next); then compound 2.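

In this assay, for the compounds shown here, the phenyl on the aromatic carbon next to the ring atom that bears a carboxy group had so far only kept its number or lost ground when substituted, and the fluoro is the first change there to bring the number down beyond the scatter, with a 3.3-fold lower number from compound 1 to compound 4 (0.52 log units; beyond the scatter). The 3-fluorophenyl also stands clear of both other substituted rings, with a 5.8-fold lower number from compound 3 to compound 4 (0.76 log units; beyond the scatter) and, the widest gap in the set, a 16-fold lower number from compound 2 to compound 4 (1.21 log units; beyond the scatter), so compound 4 now has the lowest number of the four. This position therefore does not only tolerate or penalise substitution on the phenyl: a single fluoro moves the number in the favourable direction, which neither the methoxy of compound 2 nor the nitrile and methoxy of compound 3 had shown.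

As far as these compounds go, whether a chloro, a methyl or an amine in place of the fluoro would give the same result stays open, as does whether the fluoro would keep this effect elsewhere on the phenyl. Nothing given here accounts for the difference between these rings.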